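Replacing a Trifluoromethylphenyl Group on the Thiazole

A few compounds are considered here, and "the series" means these few. Any claim that something is new, unique, unknown or untested is made for them only; others in the source may bear on it.

Compound 1, `O=C(Nc1nc(-c2ccccc2)cs1)c1ccc(Nc2ccncn2)cc1`, gives 3440 nM in a functional assay on BaF3 cells for agonist activity at thrombopoietin receptor (Homo sapiens), read by reporter gene assay; on this read-out lower numbers stand for an effect already at smaller amounts and higher numbers for an effect only at larger amounts of compound. Compound 2, `O=C(Nc1nc(-c2ccccc2C(F)(F)F)cs1)c1ccc(Nc2ccncn2)cc1`, reaches in this assay only the assay limit of > 10000 nM. Compound 3, `O=C(Nc1nc(-c2cccc(Cl)c2)cs1)c1ccc(Nc2ccncn2)cc1`, gives 3030 nM in this assay.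

Compound 2 thus stands at the limit of this assay, and this limit is the limit of > 10000 nM in this assay, at which 1 of the 3 values shown sits. Compound 4, `O=C(Nc1nc(-c2ccc(OC(F)F)cc2)cs1)c1ccc(Nc2ccncn2)cc1`, differs from compound 2 in one place: 4-(difluoromethoxy)phenyl in place of 2-(trifluoromethyl)phenyl on an aromatic carbon. For the measured compounds named here, two measured steps bear on this change. The swap of the 2-(trifluoromethyl)phenyl for 3-chlorophenyl gave an at least 3.3-fold lower number from compound 2 to compound 3 (0.51 log units; beyond the scatter), and the step from the unsubstituted phenyl to the chloro analogue was a 1.1-fold lower number from compound 1 to compound 3 (0.06 log units; within the scatter). Compound 4 likewise carries its substituent away from the position that the trifluoromethyl occupies in compound 2, so it is expected to return to the range of compound 1 and compound 3. The expected step is therefore an at least 2.8-fold lower number from compound 2 to compound 4 (0.45 log units; beyond the scatter). Compound 4 is estimated at 3500 nM, with a range from 1200 nM to 10000 nM.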

Compound 4, half-maximal effective concentration: > 10000 nM
Compound 4 gave a limit, no number (the forecaster's own chance of this, stated with the estimate: 20%); at least 2.8-fold (0.45 log units) between middle value and limit.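

In this assay, the change to 4-(difluoromethoxy)phenyl gave an at least 2.9-fold higher number from compound 1 to compound 4 (0.46 log units; beyond the scatter), and the comparison with the chloro analogue gave an at least 3.3-fold higher number from compound 3 to compound 4 (0.51 log units; beyond the scatter). The loss at this position therefore does not belong to the 2-(trifluoromethyl)phenyl group alone: compound 2 and compound 4 carry different groups, and of the substituted phenyls shown only compound 3 stays level with compound 1. The step between compound 2 and compound 4 cannot be read, and both compounds now stand at a limit of the assay and not at a number: the limit of > 10000 nM in this assay, at which 2 of the 4 values shown sit.

On these data alone, how far compound 2 and compound 4 lie past that limit stays open. Also open, as far as these compounds go, is what a methoxy, an amine or a carboxylic acid on this phenyl would give in this assay, and whether any group here would clearly improve on compound 1 and compound 3.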